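The source may report more compounds than this note shows. Statements on the series, on what has been measured and on what is new or still open speak of the compounds shown alone.

Measured so far:
compound 1, `O=C(Nc1cccc(C(F)(F)F)c1)N[C@H]1CC[C@H](O)CC1`: > 20000 nM
compound 2, `O=C(Nc1ccc(F)cc1)N[C@H]1CC[C@H](Oc2ccc(F)cc2)CC1`: 20000 nM

In a functional assay on CRL2813 cells (Homo sapiens) for cytotoxicity, read by sulforhodamine B assay, with a stated time of 5 days (a lower number here means a stronger inhibitor, a higher number a weaker inhibitor), compound 1 gives > 20000 nM, which is a limit of the assay and not a number (the limit of > 20000 nM in this assay, at which 1 of the 2 values shown sits). Compound 2 gives 20000 nM in this assay. Compound 3, `O=C(Nc1cccc(C(F)(F)F)c1)N[C@H]1CC[C@H](Oc2cccc(C(F)(F)F)c2)CC1`, differs from compound 1 by 3-(trifluoromethyl)phenyl in place of hydrogen on an oxygen on a saturated carbon. Within the data shown here, no step between measured compounds covers this change, so its size cannot be read from the series. The step expected here is an at least 1.3-fold lower number from compound 1 to compound 3 (0.12 log units; that floor lies within the scatter), which may be none beyond the scatter. Compound 3 is expected to give 15000 nM, in the range 4000 nM to 40000 nM.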

Compound 3, half-maximal inhibitory concentration: 1300 nM
The estimate for compound 3 lay 12-fold (1.06 log units) above the measured number; measured number below the stated range.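

The oxygen on a saturated carbon is a position where substitution matters: 3-(trifluoromethyl)phenyl in place of hydrogen gives an at least 15-fold lower number from compound 1 to compound 3 (1.18 log units; beyond the scatter) in this assay. Among these compounds, this is the first step read at this position, and it holds beyond the scatter. Compound 1 gives > 20000 nM, which is a limit of the assay and not a number, so the step has a floor but no known size: the limit of > 20000 nM in this assay, at which 1 of the 3 values shown sits.

From the compounds shown here alone, whether a plain phenyl, a methyl or a longer chain ending in an amine on that oxygen would give a similar number stays open. One pair cannot show whether the step carries over to other compounds sharing the core of compound 1.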